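Sulfonyl substituent and microsomal stability in the series

This account rests on a few compounds, and the source may have more. Where it says the series, first, only, none or still open, it means among the compounds named here.

Compound 3 `CC(C)OC(=O)NCCS(=O)(=O)NC(=O)c1ccc(Nc2nc(NC3(c4ccc(Cl)cc4)CC3)nc(OCC(F)(F)F)n2)cc1` stands lowest of the three measured compounds in an ADME assay on microsomes from liver (Rattus norvegicus) for metabolic stability, with a stated time of 10 min; on this read-out higher numbers stand for a more stable compound and lower numbers for a less stable compound; compound 3 gives 73%. Compound 1 `CC(C)S(=O)(=O)NC(=O)c1ccc(Nc2nc(NC3(c4ccc(Cl)cc4)CC3)nc(OCC(F)(F)F)n2)cc1` gives 96% and compound 2 `CC(C)(C)NC(=O)NCCS(=O)(=O)NC(=O)c1ccc(Nc2nc(NC3(c4ccc(Cl)cc4)CC3)nc(OCC(F)(F)F)n2)cc1` gives 93%. The two steps down to compound 3 are a number 23 percentage points lower from compound 1 to compound 3 (beyond the scatter) and a number 20 percentage points lower from compound 2 to compound 3 (beyond the scatter), whereas a number 3 percentage points lower from compound 1 to compound 2 (within the scatter).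

Compound 4 `O=C(NS(=O)(=O)C1CC1)c1ccc(Nc2nc(NC3(c4ccc(Cl)cc4)CC3)nc(OCC(F)(F)F)n2)cc1` is not yet measured. It differs from compound 3 in one place: cyclopropyl in place of 2-((isopropoxycarbonyl)amino)ethyl on a sulfonyl sulfur. Among the compounds with values here, the step that bears on this is the one between compound 1 and compound 3, in which the isopropyl group on the same sulfonyl sulfur went with the top of the set and the carbamate chain with the bottom: a number 23 percentage points lower from compound 1 to compound 3 (beyond the scatter). Compound 4 again carries a small carbon-only group on that sulfur, so a return toward compound 1 is expected. The expected step is a number 19 percentage points higher from compound 3 to compound 4 (beyond the scatter), upward and beyond the scatter. Compound 4 is therefore estimated at 92%, with a range from 80% to 100%.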

Compound 4, percent of the compound remaining: 85%
Beside the measured number, compound 4's estimate is 7 percentage points above it; the range from low to high includes it.
By their numbers in this assay, from the lowest: compound 3; then compounds 4, 2 and 1 (each within the scatter of the next, the first and the last beyond it).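

In this assay, cyclopropyl in place of the carbamate chain gives a number 12 percentage points higher from compound 3 to compound 4 (beyond the scatter) and so recovers part of the loss, while a number 11 percentage points lower from compound 1 to compound 4 (beyond the scatter) shows that cyclopropyl and isopropyl are not interchangeable on this sulfonyl sulfur. Set against the other chain, cyclopropyl gives a number 8 percentage points lower from compound 2 to compound 4 (within the scatter) and so a small carbon-only group cannot be told apart from 2-(((tert-butyl)carbamoyl)amino)ethyl here, which means chain size alone does not order the series, with compound 2 standing against any such reading. Nothing measured here bears on why these steps arise.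

Still open, as far as these compounds go, is whether a terminal amine or carboxylic acid on the ethyl chain would stay with compound 2 or fall with compound 3. Also open, from the compounds shown here alone, is whether a cyclobutyl or tert-butyl group on the sulfonyl sulfur would close the remaining distance to compound 1.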